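The compounds below may be only part of what the source reports. "The series", "measured", "known", "first", "only" and "open" are said of these compounds alone.

Measured so far in a functional assay on MCF7 cells (Homo sapiens) for inhibition, read by MTT assay, with a stated time of 72 h; a lower number here means a stronger inhibitor, a higher number a weaker inhibitor:
- compound 1 `CC(C)[C@H](NC(=O)c1cc(Cl)ccc1OCCCCNC(=O)OC(C)(C)C)C(=O)Nc1ccc([N+](=O)[O-])cc1Cl` gives > 10000 nM, which is a limit of the assay, not a number.
- compound 2 `CC(C)[C@H](NC(=O)c1cc(Cl)ccc1OCCCCN)C(=O)Nc1ccc([N+](=O)[O-])cc1Cl` gives > 10000 nM, also a limit.
- compound 3 `CC(C)[C@H](NC(=O)c1cc(Cl)ccc1OCCNC(=O)OC(C)(C)C)C(=O)Nc1cc(C(F)(F)F)cc(C(F)(F)F)c1` gives > 10000 nM, also a limit.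

Compound 1 to compound 2 is hydrogen in place of tert-butoxycarbonyl on an amine nitrogen; the step that the two limits leave unreadable from compound 1 to compound 2 cannot be read, because the limit of > 10000 nM in this assay, at which 3 of the 3 values shown sit, holds both ends. The difference between the core of compound 1 and the core of compound 3 is not broken down here.

Compound 4 `CC(C)[C@H](NC(=O)c1cc(Cl)ccc1OCCN)C(=O)Nc1cc(C(F)(F)F)cc(C(F)(F)F)c1` is not yet measured; it arises from compound 3 by hydrogen in place of tert-butoxycarbonyl on an amine nitrogen, the same change as before, at a place described in the same words. For the measured compounds named here, no measured step speaks for a direction. Going by the values given here, with every compound so far sitting at the limit, compound 4 is expected to stay at the limit as well, an estimated step that the limit leaves unreadable from compound 3 to compound 4. The estimate for compound 4 in this assay is 20000 nM, expected to span 8000 nM to 60000 nM.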

Compound 4, half-maximal inhibitory concentration: 6010 nM
The estimate for compound 4 lay 3.3-fold (0.52 log units) above the measured number; the whole stated range lies above it.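

In this assay, hydrogen in place of tert-butoxycarbonyl on the amine nitrogen of compound 3 gives an at least 1.6-fold lower number from compound 3 to compound 4 (0.22 log units; that floor lies within the scatter), and compound 4 is the only compound shown with a number rather than a limit. The same change on the core of compound 1 cannot be read, since both of its ends sit at a limit: the limit of > 10000 nM in this assay, at which 3 of the 4 values shown sit.

The change therefore has one readable instance, which shows neither that it carries over between these cores nor how large it would be on the core of compound 1.

The compounds shown leave open how a longer chain carrying the amine would read on the core of compound 3. They also leave open whether a carboxylic acid in place of that amine would give a number at all.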